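Branching a chain at the amide end of a new core

The compounds below may be only part of what the source reports. "The series", "measured", "known", "first", "only" and "open" are said of these compounds alone.

Measured compounds:
compound 1, `CCC1C(=O)N(C)c2cnc(Nc3ccc(S(=O)(=O)NCC(C)C)cc3)nc2N1c1ccn(C)n1`: 5310 nM
compound 2, `CCCCNS(=O)(=O)c1ccc(Nc2ncc3c(n2)N(c2ccn(C)n2)C(CC)C(=O)N3C)cc1`: 4320 nM
compound 3, `CCCCNC(=O)c1ccc2c(ccn2-c2ncc3c(n2)N(C2CCCC2)[C@H](CC)C(=O)N3C)c1`: 346 nM

Of the compounds shown here, three have been tested in a functional assay on HeLa cells (Homo sapiens) for antiproliferative activity, read by CCK-8 assay, with a stated time of 72 h; on this read-out higher numbers stand for weaker inhibition of growth and lower numbers for stronger inhibition of growth. Compound 2 gives 4320 nM in this assay, and compound 1, which differs from it by the change (isopropyl in place of propyl on a saturated chain carbon bound to a sulfonamide nitrogen), gives 5310 nM. The step of a 1.2-fold higher number from compound 2 to compound 1 (0.09 log units; within the scatter) is therefore a small one, and the two values cannot be told apart.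

Compound 3 carries a different core, and the difference between the two cores is not broken down here. Its value in this assay, 346 nM, is the lowest of the three numbers, and its distance from both compound 1 and compound 2 lies beyond the scatter.

The unmeasured compound 4, `CC[C@@H]1C(=O)N(C)c2cnc(-n3ccc4cc(C(=O)NCC(C)C)ccc43)nc2N1C1CCCC1`, is related to compound 3 by the change (isopropyl in place of propyl on a saturated chain carbon bound to an amide-type nitrogen). The surroundings are not identical to those in the earlier pair: there the chain carbon was bound to a sulfonamide nitrogen, here to an amide-type nitrogen, so this is the same kind of change rather than the same change. Since the earlier step of a 1.2-fold higher number from compound 2 to compound 1 (0.09 log units; within the scatter) stayed within the scatter, the step from compound 3 to compound 4 is expected to be similarly small, at a 1.2-fold higher number from compound 3 to compound 4 (0.06 log units; within the scatter). The value of compound 4 in this assay is estimated at 400 nM, with a likely range from 180 nM to 900 nM.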

Compound 4, concentration for 50% growth inhibition: 3280 nM
Compound 4: the middle estimate sits 8.2-fold (0.91 log units) below what was measured, and the stated range ends below it.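

In this assay, putting isopropyl in place of propyl on a saturated chain carbon bound to an amide-type nitrogen gives a 9.5-fold higher number from compound 3 to compound 4 (0.98 log units; beyond the scatter), which means clearly weaker inhibition of growth. Set beside the earlier pair, the same kind of change did not carry over in size from one core to the other: the same change on two cores in this assay, a 1.2-fold higher number (0.09 log units; within the scatter) from compound 2 to compound 1 and a 9.5-fold higher number (0.98 log units; beyond the scatter) from compound 3 to compound 4, 7.7-fold (0.89 log units) apart, beyond the scatter of two such steps

Among the compounds shown here, this shows that, in this series, a step that is small on one core cannot be assumed to stay small on another, but with only two pairs it does not show why the steps differ, nor whether the core, the swap from a sulfonamide nitrogen to an amide-type nitrogen, or some other difference between the two pairs is responsible.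

The compounds shown leave open how much of the value of compound 3, 346 nM, depends on the unbranched butyl chain in particular, and whether a longer chain such as hexyl would keep that value. They also leave open how the core of compound 3 would respond to a chain ending in an amine or a carboxylic acid, in place of the butyl or isobutyl chain.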